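Trifluoromethoxy in Place of Fluoro on Compound 2

This account rests on a few compounds, and the source may have more. Where it says the series, first, only, none or still open, it means among the compounds named here.

Measured so far in a functional assay on DU-145 cells (Homo sapiens) for inhibition; on this read-out higher numbers stand for weaker inhibition and lower numbers for stronger inhibition:
compound 1 `Oc1cccc(-c2cc(-c3ccccc3F)cc(-c3ccccc3O)n2)c1` gives 35600 nM
compound 2 `Oc1cccc(-c2cc(-c3ccc(F)cc3)cc(-c3ccccc3O)n2)c1` gives > 50000 nM
compound 3 `Oc1ccc(-c2cc(-c3ccc(F)cc3)cc(-c3ccccc3O)n2)cc1` gives > 50000 nM

Compound 2 stands at the limit of this assay, a limit rather than a number. Compound 3 likewise sits at a limit, as the limit of > 50000 nM in this assay, at which 2 of the 3 values shown sit, records. Compound 4 `Oc1cccc(-c2cc(-c3ccc(OC(F)(F)F)cc3)cc(-c3ccccc3O)n2)c1` differs from compound 2 by trifluoromethoxy in place of fluoro on an aromatic carbon. Going by the values given here, two measured steps touch compound 2: an at least 1.4-fold higher number from compound 1 to compound 2 (0.14 log units; that floor lies within the scatter) and a step that the two limits leave unreadable from compound 2 to compound 3. Neither involves trifluoromethoxy, and both end at a limit, so they give no readable direction for this change. Compound 4 is therefore expected to remain near that limit, with the step that the limit leaves unreadable from compound 2 to compound 4 expected to stay within the scatter. Compound 4 is estimated at 60000 nM, in the range 20000 nM to 180000 nM.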

Compound 4, half-maximal inhibitory concentration: 21100 nM
Estimate against measurement, compound 4: 2.8-fold (0.45 log units) above, and the stated range covers the measured number.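

In this assay trifluoromethoxy in place of fluoro, para to a large group, brings an at least 2.3-fold lower number from compound 2 to compound 4 (0.37 log units; beyond the scatter) and so gives the only step shown at this position that lies beyond the scatter. The earlier steps shown here could not show this, one having a floor within the scatter and the other being unreadable. Its true size stays a floor, since compound 2 stands at a limit: the limit of > 50000 nM in this assay, at which 2 of the 4 values shown sit. As far as these compounds go, how an amine, a carboxylic acid or a longer chain would read at this place stays open, as does whether trifluoromethoxy would move compound 3 in the same way.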